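Difluorophenyl in Place of Dichlorophenyl: An Expected Step

The source may report more compounds than this note shows. Statements on the series, on what has been measured and on what is new or still open speak of the compounds shown alone.

Compound 1, `Cc1nc(N(C)C(=O)NC(=O)c2c(F)cccc2F)sc1C(=O)N/N=C/c1cccc(C(F)(F)F)c1`, gives 32.7 ug/mL in a functional assay on BCG823 cells (Homo sapiens) for inhibition, read by MTT assay, with a stated time of 72 h; on this read-out higher numbers stand for weaker inhibition and lower numbers for stronger inhibition.
Compound 2, `CNc1nc(C(F)(F)F)c(C(=O)N/N=C/c2cccc(C(F)(F)F)c2)s1`, reaches only a limit of this assay, > 100 ug/mL.
Compound 3, `CN(C(=O)NC(=O)c1c(Cl)cccc1Cl)c1nc(C(F)(F)F)c(C(=O)N/N=C/c2ccccc2C(F)(F)F)s1`, gives 4.12 ug/mL in this assay.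

Compound 3 thus holds the lower of the two numbers shown, with compound 1 standing higher beyond the usual scatter; the remaining value is a limit (the limit of > 100 ug/mL in this assay, at which 1 of the 3 values shown sits). Compound 4, `CN(C(=O)NC(=O)c1c(F)cccc1F)c1nc(C(F)(F)F)c(C(=O)N/N=C/c2ccccc2C(F)(F)F)s1`, differs from compound 3 in one place: 2,6-difluorophenyl in place of 2,6-dichlorophenyl on a carbonyl carbon. For the measured compounds named here, no measured pair isolates this change; compound 1 carries the difluorophenyl but differs elsewhere as well, so its number cannot be read as this step. A small shift toward weaker inhibition, near the edge of the scatter, is expected in this assay, a 1.9-fold higher number from compound 3 to compound 4 (0.29 log units; within the scatter). For compound 4 the estimate is 8 ug/mL, spanning 3 ug/mL to 25 ug/mL.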

Compound 4, half-maximal inhibitory concentration: 17 ug/mL
Compound 4: the middle estimate sits 2.1-fold (0.33 log units) below what was measured; low and high end bracket the measured number.
By their numbers in this assay, from the lowest: compound 3; then compounds 4 and 1 (each within the scatter of the next). At a limit, above all of these: compound 2.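

In this assay, for the compounds shown here, the replacement of 2,6-dichlorophenyl by 2,6-difluorophenyl on a carbonyl carbon gives a 4.1-fold higher number from compound 3 to compound 4 (0.62 log units; beyond the scatter) and is the first step measured at this position. It shows that the position responds to this change, with the dichlorophenyl group on the lower number, though this rests on a single pair. Nothing shown accounts for the size of this step. Still open, from the compounds shown here alone, is how an unsubstituted phenyl or a 2,6-dimethylphenyl would read at this position. Also open, going by these compounds, is whether the same change would read alike on the core of compound 1.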